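This account rests on a few compounds, and the source may have more. Where it says the series, first, only, none or still open, it means among the compounds named here.

Of the compounds shown here, three sharing one core have been tested in a functional assay on UACC-62 cells (Homo sapiens) for inhibition, read by sulforhodamine B assay, with a stated time of 48 h; a lower number here means a stronger inhibitor of growth, a higher number a weaker inhibitor of growth. Compound 1 `COc1cc(-c2nn(-c3cccc(NC(=O)Nc4cc(C(F)(F)F)cc(C(F)(F)F)c4)c3)cc2-c2ccncc2)ccc1Cl` gives 661 nM. Compound 2 `COc1cc(-c2nn(-c3cccc(NC(=O)Nc4cccc(C(F)(F)F)c4)c3)cc2-c2ccncc2)ccc1Cl` gives 725 nM, and compound 3 `O=C(Nc1cccc(-n2cc(-c3ccncc3)c(-c3ccc(Cl)c(O)c3)n2)c1)Nc1cc(C(F)(F)F)cc(C(F)(F)F)c1` gives 749 nM. Compound 2 has the second highest of the three numbers, but all three lie within the usual scatter of one another, so no real order among them can be read. The step from compound 1 to compound 2, hydrogen in place of trifluoromethyl on an aromatic carbon, gave a 1.1-fold higher number from compound 1 to compound 2 (0.04 log units; within the scatter); the step from compound 1 to compound 3, hydrogen in place of methyl on an oxygen on an aromatic ring, gave a 1.1-fold higher number from compound 1 to compound 3 (0.05 log units; within the scatter). Both are within the scatter.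

Compound 4 `COc1cc(-c2nn(-c3cccc(NC(=O)c4ccccc4)c3)cc2-c2ccncc2)ccc1Cl` differs from compound 2 in another way: phenyl in place of (3-(trifluoromethyl)phenyl)amino on a carbonyl carbon. For the measured compounds named here, this is a larger change than either measured step, and no measured pair covers it; the two known steps only show that trimming a trifluoromethyl or a methyl leaves the number essentially unchanged. A step beyond the scatter, toward a higher number, is therefore expected for compound 4 in this assay, though with wide uncertainty. The estimated value for compound 4 is 1800 nM, within 500 nM to 6500 nM, which corresponds to an expected step of a 2.5-fold higher number from compound 2 to compound 4 (0.39 log units; beyond the scatter).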

Compound 4, concentration for 50% growth inhibition: 692 nM
Beside the measured number, compound 4's estimate is 2.6-fold (0.42 log units) above it; low and high end bracket the measured number.
By their numbers in this assay, from the lowest: compounds 1, 4, 2 and 3 (each within the scatter of the next).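

In this assay, phenyl in place of (3-(trifluoromethyl)phenyl)amino on the carbonyl carbon gave a 1.0-fold lower number from compound 2 to compound 4 (0.02 log units; within the scatter). The earlier steps shown here trimmed only a trifluoromethyl or a methyl, whereas this one exchanges the whole group on the carbonyl carbon, removing its nitrogen and hydrogen-bond donor along with the trifluoromethyl, and the number still does not move beyond the scatter. For this pair, then, neither that nitrogen nor that trifluoromethyl is needed to keep the growth-inhibition number where it is, although no measurement shown explains why this change is tolerated.

From the compounds shown here alone, all four compounds lie within the scatter of one another, so it remains open whether any group on this carbonyl carbon can shift the number, such as a cyclohexyl ring, a longer alkyl chain or a chain ending in an amine. Going by these compounds, it is also open whether the phenyl group would be tolerated equally well in a compound carrying the hydroxyl of compound 3 in place of the methoxy group.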